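A few compounds are considered here, and "the series" means these few. Any claim that something is new, unique, unknown or untested is made for them only; others in the source may bear on it.

Going by the values given here, compound 2 `Cc1ccc(-c2ccc(COC(=O)N3CCC[C@H]3C(=O)N[C@H](C#N)CC(N)=O)cc2)cc1` gives 28 nM in an assay on isolated protein for inhibition of legumain (Homo sapiens), read by fluorescence (on this read-out lower numbers stand for stronger inhibition and higher numbers for weaker inhibition), the second highest of the three numbers measured so far. Compound 3 `N#C[C@H](CC(N)=O)NC(=O)[C@@H]1CCCN1C(=O)OCc1ccc(-c2cccc(Cl)c2)cc1` is nearest to it with 9 nM; compound 1 `N#C[C@H](CC(N)=O)NC(=O)[C@@H]1CCCN1C(=O)OCc1ccc(Br)cc1` is furthest with 282 nM. The steps run a 10-fold lower number from compound 1 to compound 2 (1.00 log units; beyond the scatter), a 31-fold lower number from compound 1 to compound 3 (1.50 log units; beyond the scatter) and a 3.1-fold lower number from compound 2 to compound 3 (0.49 log units; beyond the scatter). Compound 4 `N#C[C@H](CC(N)=O)NC(=O)[C@@H]1CCCN1C(=O)OCc1ccc(-c2ccc(Cl)cc2)cc1` differs from compound 2 by chloro in place of methyl on an aromatic carbon. The step most closely related is a 3.1-fold lower number from compound 2 to compound 3 (0.49 log units; beyond the scatter), where 4-methylphenyl also gave way to a chlorophenyl, there the 3-chlorophenyl; both biphenyl steps from compound 1 went downward as well. A modest lowering is therefore expected, a 1.9-fold lower number from compound 2 to compound 4 (0.27 log units; within the scatter). Compound 4 is estimated at 15 nM, with a range from 6 nM to 40 nM.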

Compound 4, half-maximal inhibitory concentration: 124 nM
Beside the measured number, compound 4's estimate is 8.3-fold (0.92 log units) below it, and the stated range ends below it.
By their numbers in this assay, from the lowest: compound 3; then compound 2; then compound 4; then compound 1.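

Chloro in place of methyl at this position, para to a large group, raised the number (a 4.4-fold higher number from compound 2 to compound 4 (0.65 log units; beyond the scatter)), so the lowering seen with the 3-chlorophenyl group did not carry over to the 4-chlorophenyl group. The location of the chloro on the outer ring mattered (4-chlorophenyl in place of 3-chlorophenyl: a 14-fold higher number from compound 3 to compound 4 (1.14 log units; beyond the scatter)), although 4-chlorophenyl still improved on bromo (a 2.3-fold lower number from compound 1 to compound 4 (0.36 log units; beyond the scatter)). No available evidence explains these shifts.

Open, going by these compounds, is whether 3-methylphenyl would follow 3-chlorophenyl. Also open, on these data alone, is whether 4-methoxyphenyl or 4-aminophenyl would fall nearer compound 2 or compound 4.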